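The compounds below may be only part of what the source reports. "The series", "measured", "known", "first", "only" and "open" are said of these compounds alone.

Measured compounds:
- compound 1, `Cc1ccc(C2C(C#N)=C(N)N(c3ccc(S(N)(=O)=O)cc3)C3=C2C(=O)CCC3)cc1`: 50 ug/mL
- compound 2, `N#CC1=C(N)N(c2ccc(S(N)(=O)=O)cc2)C2=C(C(=O)CCC2)C1/C=C/c1ccccc1`: a value at the limit of the assay, > 100 ug/mL
- compound 3, `N#CC1=C(N)N(c2ccc(S(N)(=O)=O)cc2)C2=C(C(=O)CCC2)C1c1ccc([N+](=O)[O-])cc1`: 2.5 ug/mL

In a functional assay on Ehrlich cells (Mus musculus) for antiproliferative activity, read by trypan blue exclusion, with a stated time of 2 h (on this read-out lower numbers stand for stronger inhibition and higher numbers for weaker inhibition), compound 3 holds the lowest of the two numbers; its nearest neighbour is compound 1, and the step is a 20-fold lower number from compound 1 to compound 3 (1.30 log units; beyond the scatter). The value of compound 2 is only a limit, so it sits apart from both numbers.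

Compound 4, `COc1ccc2ccccc2c1C1C(C#N)=C(N)N(c2ccc(S(N)(=O)=O)cc2)C2=C1C(=O)CCC2`, changes the group on the saturated ring carbon: 2-methoxynaphthalen-1-yl in place of 4-nitrophenyl on a saturated ring carbon. Within the data shown here, two measured steps bear on this position. Exchanging the aryl group on that carbon gave an at least 40-fold lower number from compound 2 to compound 3 (1.60 log units; beyond the scatter), and changing only the substituent on the aromatic ring gave a 20-fold lower number from compound 1 to compound 3 (1.30 log units; beyond the scatter). Both steps were large, and in both the nitro-bearing compound 3 came out with the lowest number. Compound 4 loses that nitro group and carries a larger bicyclic aryl group instead, for which no direct comparison exists among the measured compounds. The expected direction is therefore a higher number in this assay, closer to compound 1 than to compound 3.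

Compound 4 is expected to give about 30 ug/mL, with a likely range from 8 ug/mL to 100 ug/mL. The estimated step is a 12-fold higher number from compound 3 to compound 4 (1.08 log units; beyond the scatter).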

Compound 4, half-maximal inhibitory concentration: 12.5 ug/mL
For compound 4 the middle estimate is 2.4-fold (0.38 log units) above the measured one; low and high end bracket the measured number.
By their numbers in this assay, from the lowest: compound 3; then compound 4; then compound 1. At a limit, above all of these: compound 2.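

In this assay, a low number at this position does not depend on the nitro group: 2-methoxynaphthalen-1-yl, which carries none, gives a 4.0-fold lower number from compound 1 to compound 4 (0.60 log units; beyond the scatter), even though it also gives a 5.0-fold higher number from compound 3 to compound 4 (0.70 log units; beyond the scatter). The saturated ring carbon therefore accepts a group with two six-membered aromatic rings, and this larger group places compound 4 within the order of the measured numbers, with compound 3 lowest and compound 1 higher. The change from 2-phenylethenyl gives an at least 8.0-fold lower number from compound 2 to compound 4 (0.90 log units; beyond the scatter), and that step has only a floor, as the value of compound 2 is a limit: the limit of > 100 ug/mL in this assay, at which 1 of the 4 values shown sits.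

The compounds shown leave open how much of the difference between compound 1 and compound 4 belongs to the second aromatic ring and how much to the methoxy group, as the two enter together in compound 4. They also leave open how an amine or a carboxylic acid would read in place of the nitro group on the phenyl ring, and so whether the low number of compound 3 is particular to nitro.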